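Compound 2 loses its 5-methyl-1H-pyrazol-3-yl group

This account rests on a few compounds, and the source may have more. Where it says the series, first, only, none or still open, it means among the compounds named here.

- compound 1 `O=C1/C(=C\Nc2cc(-c3ccco3)[nH]n2)C(c2ccccc2)=NN1c1ccccc1`: 12400 nM
- compound 2 `Cc1cc(N/C=C2\C(=O)N(c3ccccc3)N=C2c2ccccc2)n[nH]1`: 10200 nM
- compound 3 `O=C1/C(=C\Nc2cc(-c3ccccc3)[nH]n2)C(c2ccccc2)=NN1c1ccccc1`: 8750 nM

In a functional assay on MDA-MB-453 cells (Homo sapiens) for antiproliferative activity, read by MTT assay, with a stated time of 72 h (a lower number here means a stronger inhibitor, a higher number a weaker inhibitor), compound 2 stands within the scatter of the other two compounds, as a 1.2-fold lower number from compound 1 to compound 2 (0.08 log units; within the scatter) and a 1.2-fold lower number from compound 2 to compound 3 (0.07 log units; within the scatter) show. The remaining step, a 1.4-fold lower number from compound 1 to compound 3 (0.15 log units; within the scatter), is equally small. Compound 4 `O=C(O)[C@H](CO)N/C=C1\C(=O)N(c2ccccc2)N=C1c1ccccc1` arises from compound 2 by one change: 1-carboxy-2-hydroxyethyl in place of 5-methyl-1H-pyrazol-3-yl on an amine nitrogen. All three measured steps exchange a group on an aromatic carbon, and none removes the five-membered aromatic ring, so they offer only weak guidance. A move to a higher number, beyond the scatter, is expected on judgement alone: a 2.5-fold higher number from compound 2 to compound 4 (0.39 log units; beyond the scatter) is the estimated step. Compound 4 is estimated at 25000 nM, with an expected range of 7000 nM to 90000 nM.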

Compound 4, half-maximal inhibitory concentration: 49000 nM
Beside the measured number, compound 4's estimate is 2.0-fold (0.29 log units) below it; the measured number falls inside the stated range.
By their numbers in this assay, from the lowest: compounds 3, 2 and 1 (each within the scatter of the next); then compound 4.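

In this assay, among these compounds, 1-carboxy-2-hydroxyethyl in place of 5-methyl-1H-pyrazol-3-yl on the amine nitrogen gives the first step beyond the scatter, a 4.8-fold higher number from compound 2 to compound 4 (0.68 log units; beyond the scatter), whereas the exchanges on the aromatic carbon had all stayed within it. In place of 5-(furan-2-yl)-1H-pyrazol-3-yl, the same group gives a 4.0-fold higher number from compound 1 to compound 4 (0.60 log units; beyond the scatter). No measured evidence bears on this result. The compounds shown leave open whether the loss of the ring or the arrival of the carboxylic acid carries these steps. A methyl ester in place of the carboxylic acid, or a cyclohexyl group on the amine nitrogen, would separate the two.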